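A Catechol Replaces Methylthio on the Shared Core

A few compounds are considered here, and "the series" means these few. Any claim that something is new, unique, unknown or untested is made for them only; others in the source may bear on it.

Compound 1 `CCC1=C(O)c2c(oc(-c3ccc(SC)cc3)cc2=O)C(CC)(CC)C1=O` and compound 2 `CCC1=C(O)c2c(oc(-c3cc(OC)c(OC)c(OC)c3)cc2=O)C(CC)(CC)C1=O` share one core and differ only in the aryl group attached to it. In a functional assay on KB cells (Homo sapiens) for antiproliferative activity, read by sulforhodamine B assay, with a stated time of 3 days (on this read-out higher numbers stand for an effect only at larger amounts of compound and lower numbers for an effect already at smaller amounts), compound 1 reaches only a limit of the assay, > 52.1 uM, and not a number; the evidence behind it reads (the limit of > 52.1 uM in this assay, at which 1 of the 2 values shown sits). Compound 2 gives 46.7 uM in this assay. Compound 3 `CCC1=C(O)c2c(oc(-c3ccc(O)c(O)c3)cc2=O)C(CC)(CC)C1=O` carries 3,4-dihydroxyphenyl in place of 4-(methylsulfanyl)phenyl on an aromatic carbon. Among the compounds with values here, no measured step joins compound 1 to compound 3. Compound 3 is estimated at 35 uM, with a range from 10 uM to 60 uM. The step of an at least 1.4-fold lower number from compound 1 to compound 3 (0.17 log units; that floor lies within the scatter) is expected to be modest, toward smaller amounts, and may stay within the scatter.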

Compound 3, concentration for half-maximal effect: 10 uM
The estimate for compound 3 lay 3.5-fold (0.54 log units) above the measured number; low and high end bracket the measured number.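

In this assay, the aryl position next to the ring oxygen now yields a step that can be read: 3,4-dihydroxyphenyl in place of 4-(methylsulfanyl)phenyl gives an at least 5.2-fold lower number from compound 1 to compound 3 (0.71 log units; beyond the scatter). The earlier compounds shown here offered no measured step at this position. The size of this step rests on a limit of the assay held by compound 1, not on a number: the limit of > 52.1 uM in this assay, at which 1 of the 3 values shown sits.

The compounds shown leave open whether a single hydroxyl, an amine or a carboxylic acid on this phenyl group would give a similar step. They also leave open which of the two hydroxyl groups matters.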